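This account rests on a few compounds, and the source may have more. Where it says the series, first, only, none or still open, it means among the compounds named here.

Working notes on the series. Going by the values given here, compound 1 `N#Cc1ccccc1-c1cc(F)cc(-n2nnc(-c3ccccn3)n2)c1` is the reference point: in an assay for binding affinity to metabotropic glutamate receptor 5 (Rattus norvegicus) (a lower number here means a stronger inhibitor, a higher number a weaker inhibitor), compound 1 gives 4 nM, the lowest of the three numbers measured so far. Compound 2 `Fc1cc(-c2ccccn2)cc(-n2nnc(-c3ccccn3)n2)c1` gives 95 nM, and compound 3 `Cc1cnccc1-c1cc(F)cc(-n2nnc(-c3ccccn3)n2)c1` gives 33 nM. Both replacements of the 2-cyanophenyl by a six-membered aromatic ring with one hetero atom raise the number: a 24-fold higher number from compound 1 to compound 2 (1.38 log units; beyond the scatter) and an 8.3-fold higher number from compound 1 to compound 3 (0.92 log units; beyond the scatter). Between the two such analogues, a 2.9-fold lower number from compound 2 to compound 3 (0.46 log units; beyond the scatter).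

Compound 4 `Cc1cncc(-c2cc(F)cc(-n3nnc(-c4ccccn4)n3)c2)c1` carries a change of the same kind on the core of compound 1: 5-methylpyridin-3-yl in place of 2-cyanophenyl on an aromatic carbon. The two measured exchanges of the 2-cyanophenyl bear directly on it, one large and one modest, so a rise beyond the scatter is expected here as well, with the methyl-bearing ring of compound 3 and its step of an 8.3-fold higher number from compound 1 to compound 3 (0.92 log units; beyond the scatter) taken as the closer precedent. The expected step is a 7.5-fold higher number from compound 1 to compound 4 (0.88 log units; beyond the scatter). Compound 4 is therefore estimated to give 30 nM in this assay, with a range from 8 nM to 120 nM.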

Compound 4, inhibition constant: 272 nM
Estimate against measurement, compound 4: 9.1-fold (0.96 log units) below, and the stated range ends below it.
By their numbers in this assay, from the lowest: compound 1; then compound 3; then compound 2; then compound 4.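

The step for 5-methylpyridin-3-yl in this assay is the largest seen at this position (a 68-fold higher number from compound 1 to compound 4 (1.83 log units; beyond the scatter)), so a pyridine ring bearing a methyl group does not by itself stay close to compound 3. The two methylpyridine isomers are clearly not interchangeable here (an 8.2-fold higher number from compound 3 to compound 4 (0.92 log units; beyond the scatter)), and the methyl-free pyridin-2-yl ring also gives a lower number than the 5-methylpyridin-3-yl ring (a 2.9-fold higher number from compound 2 to compound 4 (0.46 log units; beyond the scatter)), so the arrangement on the ring counts for more than the presence of the methyl group. Nothing available explains these differences.

Going by these compounds, whether the low number of compound 1 depends on the nitrile or on the phenyl ring that carries it remains open. An unsubstituted phenyl, a 2-methoxyphenyl or a cyanopyridinyl ring at this place would separate the two.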